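The source may hold more compounds than are shown below. What is called first, only, known or untested is meant among the compounds shown, and "the series" means these compounds.

Measured compounds:
compound 1, `CCCSc1cc(C)c(C(=O)N=C(N)N)cc1S(C)(=O)=O` — in a functional assay for inhibition of sodium/hydrogen exchanger (Oryctolagus cuniculus) (a lower number here means a stronger inhibitor, a higher number a weaker inhibitor), compound 1 gives 6.8 nM
compound 2, `Cc1cc(Sc2cccc(Cl)c2)c(S(C)(=O)=O)cc1C(=O)N=C(N)N` — in this assay compound 2 gives 37 nM

For the measured compounds named here, compound 2 stands at the higher of the two numbers; its only neighbour is compound 1, and the step of a 5.4-fold higher number from compound 1 to compound 2 (0.74 log units; beyond the scatter) is the sole measured step. Compound 3, `Cc1cc(Sc2ccc(Cl)cc2)c(S(C)(=O)=O)cc1C(=O)N=C(N)N`, is not yet measured. The change 4-chlorophenyl in place of 3-chlorophenyl on a sulfur moves the chlorine within the ring; the measured step concerns a different exchange, propyl against 3-chlorophenyl, and does not bear on it directly. For compound 3 a change in this assay no larger than the scatter is expected, so the estimated step is no change at the digits printed from compound 2 to compound 3 (within the scatter), giving for compound 3 an expected value of 37 nM with a range from 14 nM to 100 nM.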

Compound 3, half-maximal inhibitory concentration: 19 nM
Compound 3: middle estimate off by 1.9-fold (0.29 log units), on the high side, and the stated range covers the measured number.
By their numbers in this assay, from the lowest: compound 1; then compounds 3 and 2 (each within the scatter of the next).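

In this assay, moving the chlorine gives a 1.9-fold lower number from compound 2 to compound 3 (0.29 log units; within the scatter) and so does not separate 4-chlorophenyl from 3-chlorophenyl on this sulfur. Replacing propyl with 4-chlorophenyl gives a 2.8-fold higher number from compound 1 to compound 3 (0.45 log units; beyond the scatter) in the same direction as a 5.4-fold higher number from compound 1 to compound 2 (0.74 log units; beyond the scatter), so both chlorine placements give higher numbers than propyl. Nothing available explains either change. Open, going by these compounds, is how an unsubstituted phenyl, a 2-chlorophenyl or a butyl chain on this sulfur would compare with propyl and the two chlorophenyl groups.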